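The compounds below may be only part of what the source reports. "The series", "measured", "known", "first", "only" and "open" are said of these compounds alone.

Measured in a functional assay on the whole organism (B cells) with Mus musculus as the target; on this read-out higher numbers stand for larger maximal responses and lower numbers for smaller maximal responses:

compound 1 `CCn1c(=O)n(C2OC(CO)[C@@H](O)[C@H]2O)c2nc(N)nc(O)c21`: 82%
compound 2 `C=CCn1c(=O)n(C2C=CC(CO)O2)c2nc(N)nc(O)c21`: 45%
compound 3 `C=CCn1c(=O)n(CCC(CCOCc2ccccc2)CCOCc2ccccc2)c2nc(N)nc(O)c21`: 68%

Compound 1 gives the highest of the three numbers; compound 3 lies lower and compound 2 lower still, both gaps beyond the scatter. Among the compounds with values here, compounds 2 and 3 differ from compound 1 in more than one place at once, so no single-change step between measured compounds is available.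

Compound 4 `Nc1nc(O)c2c(n1)n(C1OC(CO)[C@@H](O)[C@H]1O)c(=O)n2Cc1ccccc1` is not yet measured. It differs from compound 1 by phenyl in place of methyl on a saturated chain carbon bound to an aromatic nitrogen, the change cut one bond further out reading ethyl to benzyl. Nothing measured bears on this exact change. Given that the two compounds with a different group on this nitrogen sit below compound 1, a modest downward step is expected in this assay, beyond the scatter but not large: the expected step is a number 17 percentage points lower from compound 1 to compound 4 (beyond the scatter). Compound 4 is accordingly estimated at 65%, within a range of 40% to 90%.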

Compound 4, largest response reached (reported as maximal response), in percent of the reference or control that the assay uses: 110%
Compound 4: middle estimate off by 45 percentage points, on the low side; the whole stated range lies below it.
By their numbers in this assay, from the lowest: compound 2; then compound 3; then compound 1; then compound 4.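

In this assay, ethyl to benzyl on this nitrogen gives a number 28 percentage points higher from compound 1 to compound 4 (beyond the scatter), so with the rest of compound 1 unchanged the position accepts a six-membered aromatic ring of carbon only without loss of response. Compound 2 and compound 3 also carry a different group here, but they differ elsewhere as well and cannot isolate this position; the present step is its first single-change reading. No available evidence accounts for the rise.

Going by these compounds, whether the rise follows the aromatic ring or only the added carbons remains open; cyclohexylmethyl, phenethyl, or a benzyl group carrying a methoxy group or an amine would separate these readings. Also open, on these data alone, is whether the same change holds when the rest of the molecule is that of compound 2 or compound 3.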